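Cytotoxicity notes: aryl hydrazone variation on the shared core

The source may report more compounds than this note shows. Statements on the series, on what has been measured and on what is new or still open speak of the compounds shown alone.

The series shares one core and differs in the aryl group on a carbon with a double bond to nitrogen. Compound 1 `CN(C)CCn1cnnc1-c1cc(Oc2ccc(NC(=O)N/N=C/c3ccc(Cl)cc3Cl)cc2F)ccn1` carries 2,4-dichlorophenyl there; in an ADME assay on WI-38 cells (Homo sapiens) for cytotoxicity, read by MTT assay, with a stated time of 72 h (on this read-out higher numbers stand for weaker inhibition and lower numbers for stronger inhibition), compound 1 gives 4760 nM. Compound 2 `COc1ccc(OC)c(/C=N/NC(=O)Nc2ccc(Oc3ccnc(-c4nncn4CCN(C)C)c3)c(F)c2)c1` carries 2,5-dimethoxyphenyl; in this assay compound 2 gives "not determined" (no result reported), so no number is in hand for it. Compound 3 `CN(C)CCn1cnnc1-c1cc(Oc2ccc(NC(=O)N/N=C/c3ccc(F)cc3)cc2F)ccn1` carries 4-fluorophenyl; in this assay compound 3 gives 3980 nM, the lower of the two numbers in hand, with compound 1 nearest: a 1.2-fold lower number from compound 1 to compound 3 (0.08 log units; within the scatter). Compound 4 `CN(C)CCn1cnnc1-c1cc(Oc2ccc(NC(=O)N/N=C/c3cccc(Cl)c3Cl)cc2F)ccn1` is not yet measured; it differs from compound 3 as follows: 2,3-dichlorophenyl in place of 4-fluorophenyl on a carbon with a double bond to nitrogen. Among the measured compounds shown here, the one step that bears on this change, from compound 1 to compound 3, moved the number only within the scatter, so for compound 4 a step of about a 1.1-fold higher number from compound 3 to compound 4 (0.05 log units; within the scatter) is expected, that is nothing beyond the scatter. Compound 4 is therefore estimated at 4500 nM in this assay, with a range from 2000 nM to 10000 nM.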

Compound 4, half-maximal inhibitory concentration: 6130 nM
Estimate against measurement, compound 4: 1.4-fold (0.13 log units) below, within the range that was stated.
By their numbers in this assay, from the lowest: compounds 3, 1 and 4 (each within the scatter of the next).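

In this assay, 2,3-dichlorophenyl in place of 2,4-dichlorophenyl gives a 1.3-fold higher number from compound 1 to compound 4 (0.11 log units; within the scatter), and 2,3-dichlorophenyl in place of 4-fluorophenyl gives a 1.5-fold higher number from compound 3 to compound 4 (0.19 log units; within the scatter). Among the compounds shown here, the position on a carbon with a double bond to nitrogen now has numbers for three halogen-bearing phenyl groups, and no step among them goes beyond the scatter, so neither the change of chlorine pattern nor the change from one fluorine to two chlorines separates these compounds in this read-out. No supporting data are available to explain these results.

All the numbers in hand come from phenyl groups carrying halogen, so they say little about other kinds of group at this position. From the compounds shown here alone, whether an amine or a carboxylic acid on the phenyl ring, or a longer chain in its place, would move the number beyond the scatter remains open.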